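A few compounds are considered here, and "the series" means these few. Any claim that something is new, unique, unknown or untested is made for them only; others in the source may bear on it.

Measured compounds:

Compound 1, `CCn1c(-c2ccccc2)nc2c(NC3CCCCC3)ncnc21`: in a functional assay on CHO cells for antagonist activity at adenosine receptor A2b (Homo sapiens), read by 33P incorporation, with a stated time of 20 min (a higher number here means a weaker inhibitor, a lower number a stronger inhibitor), compound 1 gives 9020 nM.
Compound 2, `Cn1c(-c2ccccc2)nc2c(NC3CCCCC3)ncnc21`: for compound 2 this assay reports only a limit, > 30000 nM.
Compound 3, `CCCn1c(-c2ccccc2)nc2c(NC3CCOC3)ncnc21`: in this assay compound 3 gives 9080 nM.

Compound 1 and compound 2 share one core and differ only by hydrogen in place of methyl on a saturated chain carbon bound to an aromatic nitrogen. That change gave an at least 3.3-fold higher number from compound 1 to compound 2 (0.52 log units; beyond the scatter). The value of compound 2 sits at the limit of > 30000 nM in this assay, at which 1 of the 3 values shown sits, a limit and not a number, so the full size of that step is not fixed. Compound 3 carries a different core; the difference between the two cores is not broken down here. Against compound 3 stands the unmeasured compound 4, `CCn1c(-c2ccccc2)nc2c(NC3CCOC3)ncnc21`, reached by hydrogen in place of methyl on a saturated chain carbon, two bonds along the chain from an aromatic nitrogen. This is the same kind of change as the measured one, not the same: in the measured pair the carbon is bound to an aromatic nitrogen, here it is two bonds along the chain from an aromatic nitrogen. A weaker inhibitor is expected for compound 4 because an at least 3.3-fold higher number from compound 1 to compound 2 (0.52 log units; beyond the scatter) was seen on the measured pair. The step expected is a 2.0-fold higher number from compound 3 to compound 4 (0.30 log units; within the scatter). It is set smaller than the measured one, and the measured one, ending at a limit, leaves its own size open. Compound 4 is therefore expected to give about 18000 nM in this assay, with a likely span from 7000 nM to 40000 nM.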

Compound 4, inhibition constant: 11500 nM
Estimate against measurement, compound 4: 1.6-fold (0.19 log units) above; the measured number falls inside the stated range.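

On the core of compound 3, hydrogen in place of methyl on a saturated chain carbon, two bonds along the chain from an aromatic nitrogen, gave a 1.3-fold higher number from compound 3 to compound 4 (0.10 log units; within the scatter) in this assay, so propyl and ethyl cannot be told apart here. The step beyond the scatter seen on the first core therefore did not appear at a readable size on this one, although the carbon that changes is not at the same place on the chain in the two pairs, and the comparison itself stays unsettled: the same change on two cores in this assay, an at least 3.3-fold higher number (0.52 log units; beyond the scatter) from compound 1 to compound 2 and a 1.3-fold higher number (0.10 log units; within the scatter) from compound 3 to compound 4; the limit leaves it open whether they differ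

This does not show that the change behaves differently on the two cores, nor that it carries over unchanged, since compound 2 gives only a limit, > 30000 nM, and not a number.

The swap on the ring-bound nitrogen, oxolan-3-yl in place of cyclohexyl, gave a 1.3-fold higher number from compound 1 to compound 4 (0.11 log units; within the scatter), so these two groups also cannot be told apart with ethyl held fixed, and this one pair is all that speaks for that swap. Still open, on these data alone, is how a longer chain such as butyl on the aromatic nitrogen would read, or how an amine or a carboxylic acid on the oxolan-3-yl group would read.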